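The source may report more compounds than this note shows. Statements on the series, on what has been measured and on what is new or still open speak of the compounds shown alone.

Measured so far:
compound 1, `Cc1ccc(NC2=CC(=O)c3c(nc4n3[C@H]3OC[C@@H](O)[C@H]3OC4)C2=O)cc1C`: 4320 nM
compound 2, `Cc1ccc(NC2=CC(=O)c3nc4n(c3C2=O)[C@H]2OC[C@@H](O)[C@H]2OC4)cc1`: 3860 nM

Of the compounds shown here, two have been measured in a functional assay on HeLa cells (Homo sapiens) for inhibition, read by sulforhodamine B assay; on this read-out higher numbers stand for weaker inhibition and lower numbers for stronger inhibition. Compound 1 gives 4320 nM and compound 2 gives 3860 nM; compound 1 holds the higher of the two numbers, yet compound 2 lies within the usual scatter of it, so the pair is not separated on this read-out. A third compound, compound 3 `O=C1C(NC2CCCCC2)=CC(=O)c2c1nc1n2[C@H]2OC[C@@H](O)[C@H]2OC1`, awaits measurement. Against compound 1 it shows the change (cyclohexyl in place of 3,4-dimethylphenyl on an amine nitrogen); cut one bond further out, the (3,4-dimethylphenyl)amino group of compound 1 becomes a cyclohexylamino group in compound 3. Among the measured compounds shown here, no measured pair shows a step of this kind, so nothing measured guides the direction. What can be said rests on the two values alone and on the fact that a six-membered aromatic ring of carbon only leaves while a six-membered non-aromatic ring of carbon only enters, on the same amine nitrogen. The step expected here is a 1.5-fold higher number from compound 1 to compound 3 (0.18 log units; within the scatter), a move towards a higher number that need not stand beyond the scatter. Compound 3 is estimated at 6500 nM in this assay, with a range from 2200 nM to 20000 nM.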

Compound 3, half-maximal inhibitory concentration: > 16000 nM
Compound 3 was reported as a limit (the forecaster's own chance of this, stated with the estimate: 10%); middle value at least 2.4-fold (0.39 log units) from the limit.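

In this assay, among the compounds shown here, cyclohexyl in place of 3,4-dimethylphenyl on an amine nitrogen gives an at least 3.7-fold higher number from compound 1 to compound 3 (0.56 log units; beyond the scatter), the first step that stands beyond the scatter, and it shows that inhibition at this position depends on the group the amine nitrogen carries. Compound 3 is reported only as a limit, > 16000 nM. The step therefore sets a minimum size and not a measured distance, so how much weaker compound 3 is than compound 1 remains unknown, and the comparison rests on a single limit value: the limit of > 16000 nM in this assay, at which 1 of the 3 values shown sits.

The change removes the aromatic ring and the two methyl groups together, so the compounds shown do not tell which of these matters, and a plain phenyl or a 3,4-dimethylcyclohexyl group on the same amine nitrogen would separate the two. They also leave open how a benzyl group, a short straight alkyl chain or a phenyl ring bearing a methoxy group or a chlorine atom would behave at this position on the shared core.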